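This account rests on a few compounds, and the source may have more. Where it says the series, first, only, none or still open, it means among the compounds named here.

Working notes on the series. Compound 1 `Cc1ccc(-c2cc(N3CCC(CCNS(N)(=O)=O)CC3)ncn2)cc1`, compound 2 `NS(=O)(=O)NCCC1CCN(c2cc(-c3ccc(Cl)cc3)ncn2)CC1` and compound 3 `NS(=O)(=O)NCCC1CCN(c2cc(-c3cccc(Cl)c3)ncn2)CC1` share one core and differ only in the aryl group on it. In a functional assay on HT-29 cells (Homo sapiens) for antiproliferative activity, read by sulforhodamine B assay, with a stated time of 48 h (on this read-out higher numbers stand for weaker inhibition of growth and lower numbers for stronger inhibition of growth), compound 1 gives 52300 nM, compound 2 gives 30500 nM and compound 3 gives 31600 nM. By number compound 3 stands second highest of the three, nearest compound 2 and furthest from compound 1, though both gaps lie within the scatter. Compound 4 `NS(=O)(=O)NCCC1CCN(c2cc(-c3ccccc3F)ncn2)CC1` differs from compound 3 by 2-fluorophenyl in place of 3-chlorophenyl on an aromatic carbon. Among the measured compounds shown here, the steps that bear on this are the earlier aryl swaps: a 1.0-fold higher number from compound 2 to compound 3 (0.02 log units; within the scatter), a 1.7-fold lower number from compound 1 to compound 3 (0.22 log units; within the scatter) and a 1.7-fold lower number from compound 1 to compound 2 (0.23 log units; within the scatter), none beyond the scatter. Another aryl swap is therefore expected to give no step beyond the scatter in this assay, the expected step being a 1.0-fold higher number from compound 3 to compound 4 (0.02 log units; within the scatter). Compound 4 is estimated at 33000 nM, within 14000 nM to 75000 nM.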

Compound 4, concentration for 50% growth inhibition: 51800 nM
Compound 4: the middle estimate sits 1.6-fold (0.20 log units) below what was measured; the range from low to high includes it.
By their numbers in this assay, from the lowest: compounds 2, 3, 4 and 1 (each within the scatter of the next).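

In this assay the 2-fluorophenyl group on this aromatic carbon stays within the scatter of all three earlier aryl groups: 3-chlorophenyl (a 1.6-fold higher number from compound 3 to compound 4 (0.21 log units; within the scatter)), 4-chlorophenyl (a 1.7-fold higher number from compound 2 to compound 4 (0.23 log units; within the scatter)) and 4-methylphenyl (a 1.0-fold lower number from compound 1 to compound 4 (0.00 log units; within the scatter)). The four aryl groups shown, now including one with fluorine, therefore give no step beyond the scatter at this position. Nothing available gives a reason for these steps. Still open, from the compounds shown here alone, is whether an aryl ring carrying an amine or a carboxylic acid gives a step beyond the scatter here. The same holds for a longer chain in place of the aryl group.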